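The source may hold more compounds than are shown below. What is called first, only, known or untested is meant among the compounds shown, and "the series" means these compounds.

Among the measured compounds shown here, in a functional assay on HeLa cells (Homo sapiens) for antiproliferative activity, read by MTT assay, with a stated time of 72 h (a higher number here means a weaker inhibitor, a lower number a stronger inhibitor), compound 1 `COc1cc(C(=O)c2sc3ccccc3c2-c2ccc(Cl)cc2)cc(OC)c1OC` gives 5200 nM and compound 2 `COc1cc(C(=O)c2sc3ccccc3c2-c2ccc(C)cc2)cc(OC)c1OC` gives 3700 nM, so compound 2 stands level with its only measured neighbour. Compound 3 `COc1ccc(-c2c(C(=O)c3cc(OC)c(OC)c(OC)c3)sc3ccccc23)cc1` keeps the shared core and differs from compound 2 as follows: methoxy in place of methyl on an aromatic carbon. For the measured compounds named here, the one measured step that bears on this is a 1.4-fold lower number from compound 1 to compound 2 (0.15 log units; within the scatter), with methyl in place of chloro on an aromatic carbon. On that single small step, the expected change is a 1.5-fold lower number from compound 2 to compound 3 (0.17 log units; within the scatter), so none beyond the scatter is expected. For compound 3 the estimated value is 2500 nM, with an expected range of 600 nM to 7000 nM.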

Compound 3, half-maximal inhibitory concentration: 4200 nM
The estimate for compound 3 lay 1.7-fold (0.23 log units) below the measured number, within the range that was stated.
By their numbers in this assay, from the lowest: compounds 2, 3 and 1 (each within the scatter of the next).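

Putting methoxy in place of methyl gives a 1.1-fold higher number from compound 2 to compound 3 (0.06 log units; within the scatter), and methoxy in place of chloro gives a 1.2-fold lower number from compound 1 to compound 3 (0.09 log units; within the scatter). A third group at this position, para to a large group, therefore still leaves the compounds indistinguishable, even though methoxy brings a hydrogen-bond acceptor that neither methyl nor chloro has. Nothing available explains this lack of difference. Going by these compounds, whether an amine, a carboxylic acid or a longer chain here would move the number beyond the scatter stays open. So does whether these three groups would also match elsewhere on the shared core.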